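The source may hold more compounds than are shown below. What is called first, only, known or untested is meant among the compounds shown, and "the series" means these compounds.

Working notes on the series.

Among the measured compounds shown here, compound 1 `COc1cc(C)cc(-c2c(-c3ccnc(-c4ccc(N(C)C)cc4)c3)cnn2CC#N)c1` gives -18% in a functional assay on BT-549 cells (Homo sapiens) for cytotoxicity, read by sulforhodamine B assay, with a stated time of 48 h, tested at 100 nM (on this read-out higher numbers stand for a weaker effect at the one concentration tested and lower numbers for a stronger effect), the lowest of the three numbers measured so far. Compound 2 `COc1cc(C)cc(-c2nn(CC#N)cc2-c2ccc(-c3cccc(C(C)=O)c3)nc2)c1` gives 85% and compound 3 `Cc1cc(O)cc(-c2nn(CC#N)cc2-c2ccnc(-c3ccc(N(C)C)cc3)c2)c1` gives 87%, both beyond the scatter from compound 1. Compound 2 and compound 3 lie within the scatter of each other. For the measured compounds named here, no two measured compounds differ in a single place, so no step size is known from measurement.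

Compound 4 `COc1cc(C)cc(-c2c(-c3ccnc(-c4ccc(C(C)=O)cc4)c3)cnn2CC#N)c1` departs from compound 1 by acetyl in place of dimethylamino on an aromatic carbon. An acetyl group is also present in compound 2, though on a differently arranged core, where the effect was weak. A step of a number 73 percentage points higher from compound 1 to compound 4 (beyond the scatter) toward a weaker effect is therefore expected, wide in its range. Compound 4 is expected to give 55%, between 15% and 90%.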

Compound 4, a percentage reported as activity, at one concentration (the size of the read-out at that concentration, not a potency): 82%
Estimate against measurement, compound 4: 27 percentage points below; low and high end bracket the measured number.
By their numbers in this assay, from the lowest: compound 1; then compounds 4, 2 and 3 (each within the scatter of the next).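

In this assay, acetyl in place of dimethylamino gives a number 100 percentage points higher from compound 1 to compound 4 (beyond the scatter) and so puts a first measured size on a single change in the series. This position, on an aromatic carbon para to a large group, is therefore sensitive to the group it carries. The two groups match in heavy atoms, hydrogen-bond donors and acceptors as counted, so those counts do not account for the step in this pair, and no measurement at hand gives a reason for it.

From the compounds shown here alone, whether the effect of compound 1 requires dimethylamino specifically remains open. A primary amine, a morpholine ring or a methoxy group at this position would test that.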